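Working notes: from 4-methylpiperazin-1-yl to dimethylamino

The compounds below may be only part of what the source reports. "The series", "measured", "known", "first", "only" and "open" are said of these compounds alone.

Measured in an ADME assay on Huh-7 cells (Homo sapiens) for cytotoxicity, read by CellTiter-Blue; on this read-out higher numbers stand for weaker inhibition and lower numbers for stronger inhibition:
- compound 1 `CCOC(=O)c1c(CS(=O)(=O)c2ccccc2)n(C)c2ccc(Cn3ccnc3)cc12` gives 5000 nM
- compound 2 `CCOC(=O)c1c(CS(=O)(=O)c2ccccc2)n(C)c2ccc(CN3CCCNCC3)cc12` gives 12000 nM
- compound 3 `CCOC(=O)c1c(CS(=O)(=O)c2ccccc2)n(C)c2ccc(CN3CCN(C)CC3)cc12` gives 4000 nM

Compound 3 sits at the low end of the numbers in this assay. Its nearest neighbour lies within the scatter: a 1.3-fold lower number from compound 1 to compound 3 (0.10 log units; within the scatter). Its furthest neighbour lies beyond it: a 3.0-fold lower number from compound 2 to compound 3 (0.48 log units; beyond the scatter).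

Compound 4 `CCOC(=O)c1c(CS(=O)(=O)c2ccccc2)n(C)c2ccc(CN(C)C)cc12` keeps the shared core and carries dimethylamino in place of 4-methylpiperazin-1-yl on a saturated chain carbon bound to an aromatic carbon. Going by the values given here, no measured step makes this exact change. The closest evidence is the other exchanges at the same place, and the largest of these is modest: a 3.0-fold lower number from compound 2 to compound 3 (0.48 log units; beyond the scatter). The remaining one beyond the scatter is also modest: a 2.4-fold higher number from compound 1 to compound 2 (0.38 log units; beyond the scatter). A step of similar or smaller size is therefore expected. Compound 3 already stands low at 4000 nM, so a slightly higher number is the expected direction. The estimated step is a 1.5-fold higher number from compound 3 to compound 4 (0.18 log units; within the scatter). For compound 4 the estimate is 6000 nM, with an expected range of 2500 nM to 14000 nM.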

Compound 4, half-maximal inhibitory concentration: 10000 nM
Compound 4: the middle estimate sits 1.7-fold (0.22 log units) below what was measured, within the range that was stated.
By their numbers in this assay, from the lowest: compounds 3, 1, 4 and 2 (each within the scatter of the next, the first and the last beyond it).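

In this assay, at this place, on a saturated chain carbon bound to an aromatic carbon, the low number of the ring-bearing 4-methylpiperazin-1-yl group does not carry over to the open dimethylamino group (a 2.5-fold higher number from compound 3 to compound 4 (0.40 log units; beyond the scatter)). This modest step is the first one shown that goes from a ring to no ring, yet dimethylamino stays within the scatter of both other groups (a 1.2-fold lower number from compound 2 to compound 4 (0.08 log units; within the scatter); a 2.0-fold higher number from compound 1 to compound 4 (0.30 log units; within the scatter)). Removing the ring therefore moves the number no further than the exchange of one ring for another (a 3.0-fold lower number from compound 2 to compound 3 (0.48 log units; beyond the scatter)), and no measurement at hand accounts for either step.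

Diethylamino or morpholin-4-yl at this place would show whether open chains and rings stay this close. A carboxylic acid there remains an open case, as does the same exchange of 4-methylpiperazin-1-yl for dimethylamino on a different core.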